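The source may hold more compounds than are shown below. What is called first, only, known or untested is meant among the compounds shown, and "the series" means these compounds.

Measured compounds:
- compound 1, `CO/N=c1\[nH]cnc2c1[n+](C/C=C(\C)CC/C=C(/C)CCC=C(C)C)cn2C`: 1400 nM
- compound 2, `CC(C)=CCC/C(C)=C\CC/C(C)=C/C[n+]1cn(C)c2nc[nH]/c(=N\OCc3ccccc3)c21`: 7550 nM
- compound 3, `CO/N=c1\[nH]cnc2c1[n+](C/C=C(\C)CC/C=C(\C)CC/C=C(\C)CCC=C(C)C)cn2CCC#N`: 3330 nM

All three were run in a functional assay on U-937/GTB cells (Homo sapiens) for cytotoxicity; on this read-out higher numbers stand for weaker inhibition and lower numbers for stronger inhibition. Compound 1 differs from compound 2 by phenyl in place of hydrogen on a saturated chain carbon bound to an oxygen; this change gave a 5.4-fold higher number from compound 1 to compound 2 (0.73 log units; beyond the scatter). Compound 3 shares no single-point relationship with compound 1; the difference between the two cores is not broken down here. Compound 3 gives the second-highest number of the three in this assay, between compound 1 and compound 2.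

Compound 4, `CC(C)=CCC/C(C)=C/CC/C(C)=C/CC/C(C)=C/C[n+]1cn(CCC#N)c2nc[nH]/c(=N\OCc3ccccc3)c21`, is not yet measured. It differs from compound 3 by phenyl in place of hydrogen on a saturated chain carbon bound to an oxygen, the same change already seen from compound 1 to compound 2, at the same place. Because a 5.4-fold higher number from compound 1 to compound 2 (0.73 log units; beyond the scatter) was beyond the scatter, a step of similar size is expected here. The step from compound 3 to compound 4 is estimated as a 4.5-fold higher number from compound 3 to compound 4 (0.65 log units; beyond the scatter). Compound 4 is therefore estimated at 15000 nM, expected to fall between 6000 nM and 40000 nM.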

Compound 4, half-maximal inhibitory concentration: 24200 nM
Beside the measured number, compound 4's estimate is 1.6-fold (0.21 log units) below it; the range from low to high includes it.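

In this assay, the change from methoxy to benzyloxy carries over to a second core, giving a 7.3-fold higher number from compound 3 to compound 4 (0.86 log units; beyond the scatter). The two steps point the same way and agree in size: the same change on two cores in this assay, a 5.4-fold higher number (0.73 log units; beyond the scatter) from compound 1 to compound 2 and a 7.3-fold higher number (0.86 log units; beyond the scatter) from compound 3 to compound 4, 1.3-fold (0.13 log units) apart, within the scatter of two such steps. Among the compounds shown here, two pairs show only that the step transfers for these cores; they do not show that it holds on any further core, and they give no cause for the weaker inhibition.

Open, as far as these compounds go, is how other groups at this oxygen would behave, such as ethyl, a longer chain, or a benzyl ring carrying fluorine or an amine. Also open, from the compounds shown here alone, is whether a carboxylic acid at the end of that chain would depart from this step.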